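This account rests on a few compounds, and the source may have more. Where it says the series, first, only, none or still open, it means among the compounds named here.

In an ADME assay on THP-1 cells (Homo sapiens) for cytotoxicity, read by flow cytometry and propidium iodide staining, with a stated time of 72 h (on this read-out lower numbers stand for stronger inhibition and higher numbers for weaker inhibition), compound 2 (`CC(=O)Nc1ccc2oc(-c3ccccc3)c(O)c(=O)c2c1`) gives 36000 nM and stands in the middle of the three measured numbers, with compound 1 (`CC(=O)Nc1ccc2oc(-c3ccccc3)cc(=O)c2c1`) higher at 97000 nM and compound 3 (`COc1ccc(-c2oc3ccc(NC(C)=O)cc3c(=O)c2O)cc1`) lower at 9000 nM on this read-out. Compound 4 (`COc1c(-c2ccccc2)oc2ccc(NC(C)=O)cc2c1=O`) differs from compound 2 by one change, methyl in place of hydrogen on an oxygen on an aromatic ring, which turns hydroxy into methoxy. Two modest measured steps bear on it. Hydroxy in place of hydrogen on an aromatic carbon gave a 2.7-fold lower number from compound 1 to compound 2 (0.43 log units; beyond the scatter) and this is the group now changed, so capping it might lead to a higher number. Adding a methoxy group to a carbon gave a 4.0-fold lower number from compound 2 to compound 3 (0.60 log units; beyond the scatter) and that hints at a lower number, although that methoxy does not sit on this oxygen. With these two pulling in opposite directions, the step expected in this assay is a 1.1-fold higher number from compound 2 to compound 4 (0.05 log units; within the scatter) with no move beyond the scatter anticipated. For compound 4 the estimated value is 40000 nM with an expected range from 15000 nM to 100000 nM in this measurement.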

Compound 4, half-maximal inhibitory concentration: > 125000 nM
Compound 4 gave a limit, no number; the forecaster's own chance of this, stated with the estimate: 15%; middle value at least 3.1-fold (0.49 log units) away from the limit.
By their numbers in this assay, from the lowest: compound 3; then compound 2; then compound 1. At a limit, above all of these: compound 4.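

Methyl in place of hydrogen on the oxygen gave an at least 3.4-fold higher number from compound 2 to compound 4 (0.54 log units; beyond the scatter), so this oxygen is a place where turning hydroxy into methoxy moves the number upward, which the earlier compounds could not show. Compound 4 stands at a limit, > 125000 nM, and not at a number. Set against the core of compound 1, which has no group on that carbon, methoxy in place of hydrogen on an aromatic carbon gave an at least 1.2-fold higher number from compound 1 to compound 4 (0.11 log units; that floor lies within the scatter), and the same change does not read alike on the two cores: the same change on two cores in this assay, a 4.0-fold lower number (0.60 log units; beyond the scatter) from compound 2 to compound 3 and an at least 1.2-fold higher number (0.11 log units; that floor lies within the scatter) from compound 1 to compound 4, at least 5.1-fold (0.71 log units) apart, beyond the scatter of two such steps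

Going by these compounds, how far the number of compound 4 lies past its limit stays open. Also open, on these data alone, is whether an ethyl group or a longer chain on this oxygen would follow methoxy, or whether only the free hydroxy gives the lower numbers seen here.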